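Solubility notes: pyridinylmethyl in place of chlorobenzyl

A few compounds are considered here, and "the series" means these few. Any claim that something is new, unique, unknown or untested is made for them only; others in the source may bear on it.

Measured in a physicochemical assay for solubility, using the shake flask method, in simulated intestinal fluid, measured as kinetic solubility, with a stated time of 2 h, at 25 degrees C, at pH 6.5 (on this read-out lower numbers stand for lower solubility and higher numbers for higher solubility), so far:
compound 1 `Cc1nnc(-c2nc(C)c3c(c2N)C(=O)N(Cc2ccccc2)C3=O)o1`: < 5000 nM, a limit of the assay
compound 2 `Cc1nc(C(=O)NC#N)c(N)c2c1C(=O)N(Cc1ccccc1)C2=O`: 185000 nM
compound 3 `Cc1noc(-c2nc(C)c3c(c2N)C(=O)N(Cc2ccc(Cl)cc2)C3=O)n1`: < 5000 nM, a limit of the assay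

Going by the values given here, the one measured step is an at least 37-fold higher number from compound 1 to compound 2 (1.56 log units; beyond the scatter). Compound 3 stands at the limit, and the limit of < 5000 nM in this assay, at which 2 of the 3 values shown sit, shows compound 3 shares it with compound 1, so no number is known for compound 3 itself.

Compound 4 `Cc1noc(-c2nc(C)c3c(c2N)C(=O)N(Cc2ccncc2)C3=O)n1` differs from compound 3 by pyridin-4-yl in place of 4-chlorophenyl on a saturated chain carbon bound to an amide-type nitrogen in a ring. Among the compounds with values here, no measured step concerns a group on the saturated chain carbon bound to the amide-type nitrogen; the step from compound 1 to compound 2 sits elsewhere and does not bear on it. Because compound 3 only has < 5000 nM, any change can be registered solely as a rise. A modest step of an at least 1.6-fold higher number from compound 3 to compound 4 (0.20 log units; that floor lies within the scatter) is expected. Compound 4 is estimated at 8000 nM, between 2000 nM and 40000 nM.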

Compound 4, solubility: 26400 nM
The estimate for compound 4 lay 3.3-fold (0.52 log units) below the measured number, within the range that was stated.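

Pyridin-4-yl in place of 4-chlorophenyl on a saturated chain carbon bound to an amide-type nitrogen in a ring gives the first step read at this place in this assay: an at least 5.2-fold higher number from compound 3 to compound 4 (0.72 log units; beyond the scatter). That step is a floor, not a size. Compound 3 gives < 5000 nM, a limit of the assay.

Open, as far as these compounds go, is whether pyridin-2-yl, pyridin-3-yl or a saturated amine such as piperidin-4-yl would give a similar step at this place. Also open, from the compounds shown here alone, is whether the same change would give a similar step with the cyanocarbamoyl group of compound 2 in the molecule.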